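Aryl sulfonyl exchange on a shared core

The source may report more compounds than this note shows. Statements on the series, on what has been measured and on what is new or still open speak of the compounds shown alone.

Compound 1, `COc1ccc(S(=O)(=O)NC2=NCCN2C(=S)SN2CCn3c2nsc3=S)cc1OC`, in a functional assay on KYSE-510 cells (Homo sapiens) for antiproliferative activity, read by crystal violet staining, with a stated time of 96 h; on this read-out lower numbers stand for stronger inhibition of growth and higher numbers for weaker inhibition of growth: >= 20000 nM
Compound 2, `O=S(=O)(NC1=NCCN1C(=S)SN1CCn2c1nsc2=S)c1ccc(F)c(Cl)c1`, in this assay: >= 20000 nM

In this assay compound 1 gives only a limit, >= 20000 nM. Compound 2 also gives only a limit in this assay, >= 20000 nM. The step that the two limits leave unreadable from compound 1 to compound 2 therefore cannot be read, as the limit of >= 20000 nM in this assay, at which 2 of the 2 values shown sit, shows. Compound 3, `O=S(=O)(NC1=NCCN1C(=S)SN1CCn2c1nsc2=S)c1cccc2ccccc12`, differs from compound 2 by naphthalen-1-yl in place of 3-chloro-4-fluorophenyl on a sulfonyl sulfur. Going by the values given here, the single measured step at this sulfonyl sulfur is unreadable, so neither size nor direction can be drawn from it. Compound 3 is expected to remain near the same limit, the expected step being a number no higher from compound 2 to compound 3 (the limit leaves the size open). Compound 3 is thus estimated at 20000 nM, between 5000 nM and 40000 nM.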

Compound 3, concentration for 50% growth inhibition: >= 20000 nM
Compound 3: no number, only a limit; the forecaster's own chance of this, stated with the estimate: 75%; the middle value lies on the limit itself.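

Going by these compounds alone, compound 3, like compound 1 and compound 2, gives only a limit in this assay, so no step among them can be read: the limit of >= 20000 nM in this assay, at which 3 of the 3 values shown sit. The compounds shown leave open whether the group on the sulfonyl sulfur affects growth inhibition at all.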